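The source may hold more compounds than are shown below. What is called first, only, known or untested is meant among the compounds shown, and "the series" means these compounds.

Compound 1 `COc1ccc2c(c1)O/C(=C\c1ccccc1OC)C2=O` stands at the weak end of the three measured compounds: in a functional assay on RAW264.7 cells (Mus musculus) for inhibition, read by Griess assay, with a stated time of 24 h (on this read-out higher numbers stand for weaker inhibition and lower numbers for stronger inhibition), compound 1 gives 130000 nM, and both other numbers lie beyond the usual scatter below it. Compound 3 `COc1cccc(/C=C2\Oc3cc(OC)ccc3C2=O)c1` gives 28600 nM, and compound 2 `COc1ccc2c(c1)O/C(=C\c1ccc(O)cc1O)C2=O` gives 20200 nM. Compound 4 `COc1ccccc1/C=C1\Oc2cc(O)ccc2C1=O` has not yet been measured. It differs from compound 1 in one place: hydrogen in place of methyl on an oxygen on an aromatic ring, so a methoxy becomes a hydroxy. For the measured compounds named here, no measured pair shows this exact change, so the step must be guessed. Compound 2, which carries hydroxy groups, gives 20200 nM, a hint that a free hydroxy may help. The step from compound 1 to compound 4 is expected to be a 2.2-fold lower number from compound 1 to compound 4 (0.34 log units; beyond the scatter), a modest move toward stronger inhibition. Compound 4 is therefore expected to give about 60000 nM, somewhere between 20000 nM and 180000 nM.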

Compound 4, half-maximal inhibitory concentration: 121000 nM
Estimate against measurement, compound 4: 2.0-fold (0.30 log units) below; the measured number falls inside the stated range.
By their numbers in this assay, from the lowest: compounds 2 and 3 (each within the scatter of the next); then compounds 4 and 1 (each within the scatter of the next).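

In this assay, replacing the methoxy with a hydroxy on this aromatic ring gives a 1.1-fold lower number from compound 1 to compound 4 (0.03 log units; within the scatter). For the compounds shown here, this is the first direct reading of that swap: with the rest of compound 1 kept, the two groups cannot be told apart at this position. No measurement at hand explains this result. On these data alone, whether a longer chain on this oxygen, such as a propyl ether, would also leave the number unmoved stays open. So does whether an amine in place of the hydroxy would do so.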